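From vinyl to but-1-en-1-yl on the carbonyl carbon

The source may report more compounds than this note shows. Statements on the series, on what has been measured and on what is new or still open speak of the compounds shown alone.

In a functional assay on A549 cells (Homo sapiens) for antiproliferative activity, read by MTT assay, with a stated time of 72 h (a lower number here means a stronger inhibitor, a higher number a weaker inhibitor), compound 3 `C=CC(=O)Nc1cccc(Oc2nc(Nc3ccc(OC)nc3)nc3c2CSCC3)c1` gives 14600 nM and stands within the scatter of the two other measured compounds. Compound 1 `CC/C=C/C(=O)Nc1cccc(Oc2nc(Nc3cccc(OC)c3)nc3c2CSCC3)c1` gives 17200 nM and compound 2 `CC/C=C/C(=O)Nc1cccc(Oc2nc(Nc3ccc(OC)cc3)nc3c2CSCC3)c1` gives 20100 nM in the same test.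

Compound 4 `CC/C=C/C(=O)Nc1cccc(Oc2nc(Nc3ccc(OC)nc3)nc3c2CSCC3)c1` differs from compound 3 in one place, with but-1-en-1-yl in place of vinyl on a carbonyl carbon, and but-1-en-1-yl in place of vinyl on a carbonyl carbon sums up that change. Among the compounds with values here, the only measured step, a 1.2-fold higher number from compound 1 to compound 2 (0.07 log units; within the scatter), lies within the scatter and concerns 4-methoxyphenyl in place of 3-methoxyphenyl, so no measured step isolates the change at the carbonyl carbon. Compound 1 at 17200 nM and compound 2 at 20100 nM already carry but-1-en-1-yl, and both sit within the scatter of compound 3 even though it also differs from them elsewhere. No step beyond the scatter is therefore expected in this assay for this change. The expected step is a 1.2-fold higher number from compound 3 to compound 4 (0.07 log units; within the scatter) and would stay within the scatter. The estimated value for compound 4 is 17000 nM with an expected range from 9000 nM to 32000 nM in this test.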

Compound 4, half-maximal inhibitory concentration: 13100 nM
Compound 4: the middle estimate sits 1.3-fold (0.11 log units) above what was measured; the range from low to high includes it.
By their numbers in this assay, from the lowest: compounds 4, 3, 1 and 2 (each within the scatter of the next).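

In this assay the change at the carbonyl carbon can now be read alone: vinyl to but-1-en-1-yl gives a 1.1-fold lower number from compound 3 to compound 4 (0.05 log units; within the scatter) and so does not separate the two groups when 6-methoxypyridin-3-yl sits on the nitrogen. With but-1-en-1-yl held constant, replacing 4-methoxyphenyl with 6-methoxypyridin-3-yl gives a 1.5-fold lower number from compound 2 to compound 4 (0.19 log units; within the scatter) and replacing 3-methoxyphenyl with it gives a 1.3-fold lower number from compound 1 to compound 4 (0.12 log units; within the scatter), so neither swap on that nitrogen separates these compounds either. No measurement shown here offers an explanation for these results.

Going by these compounds, it remains open whether a longer chain on the carbonyl carbon would produce a step beyond the scatter. The same question stands for a dimethylamine or a carboxylic acid carried on the but-1-en-1-yl chain.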